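The source may report more compounds than this note shows. Statements on the series, on what has been measured and on what is new or still open speak of the compounds shown alone.

Of the compounds shown here, three sharing one core have been measured in an in vitro assay on Sf21 cells for inhibition of high affinity 3',5'-cyclic-AMP phosphodiesterase 7A (Homo sapiens), read by scintillation proximity assay, with a stated time of 30 min; a higher number here means a weaker inhibitor, a lower number a stronger inhibitor. Compound 1 `CNC(=O)c1ccc(NC(=O)c2cn(Cc3c(F)cccc3F)c3ccc(=O)[nH]c3c2=O)cc1` gives 29 nM, compound 2 `CS(=O)(=O)c1ccc(NC(=O)c2cn(Cc3c(F)cccc3F)c3ccc(=O)[nH]c3c2=O)cc1` gives 27 nM, and compound 3 `O=C(Nc1ccc(S(=O)(=O)Nc2nccs2)cc1)c1cn(Cc2c(F)cccc2F)c2ccc(=O)[nH]c2c1=O` gives 25 nM, the lowest of the three numbers, though its steps from the others, a 1.2-fold lower number from compound 1 to compound 3 (0.06 log units; within the scatter) and a 1.1-fold lower number from compound 2 to compound 3 (0.03 log units; within the scatter), both lie within the scatter. Compound 4 `CSc1ccc(NC(=O)c2cn(Cc3c(F)cccc3F)c3ccc(=O)[nH]c3c2=O)cc1` differs from compound 3 by methylsulfanyl in place of (1,3-thiazol-2-yl)sulfamoyl on an aromatic carbon. Within the data shown here, the steps that bear on this change are those exchanging the same group on the same aromatic carbon: a 1.1-fold lower number from compound 1 to compound 2 (0.03 log units; within the scatter), a 1.2-fold lower number from compound 1 to compound 3 (0.06 log units; within the scatter) and a 1.1-fold lower number from compound 2 to compound 3 (0.03 log units; within the scatter), every one within the scatter. On that basis no step beyond the scatter is expected for compound 4, a 1.6-fold higher number from compound 3 to compound 4 (0.20 log units; within the scatter), although the entering group is unlike any of the measured ones, which widens the uncertainty. Compound 4 is therefore estimated at 40 nM, between 15 nM and 130 nM.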

Compound 4, half-maximal inhibitory concentration: 86 nM
Compound 4: middle estimate off by 2.2-fold (0.33 log units), on the low side; measured number inside the range.
By their numbers in this assay, from the lowest: compounds 3, 2 and 1 (each within the scatter of the next); then compound 4.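

This position on the aromatic ring does respond to the group it carries: with methylsulfanyl there, compound 4 is a weaker inhibitor in each comparison (a 3.4-fold higher number from compound 3 to compound 4 (0.54 log units; beyond the scatter)), (a 3.2-fold higher number from compound 2 to compound 4 (0.50 log units; beyond the scatter)) and (a 3.0-fold higher number from compound 1 to compound 4 (0.47 log units; beyond the scatter)). Methylcarbamoyl, methylsulfonyl and (1,3-thiazol-2-yl)sulfamoyl lie within the scatter of one another, so only methylsulfanyl stands apart among these four groups. Nothing measured here accounts for this difference. Still open, from the compounds shown here alone, is whether an amine, a carboxylic acid or a plain methyl on this carbon would match compound 4 or the other three.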